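The source may hold more compounds than are shown below. What is called first, only, known or untested is meant among the compounds shown, and "the series" means these compounds.

Measured so far:
compound 1 `Fc1cccc(Nc2nc3nonc3nc2Nc2ccccc2F)c1`: 190 nM
compound 2 `Oc1nc2nonc2nc1Nc1ccc(OC(F)(F)F)c(Cl)c1`: 3000 nM

In an assay on mitochondria from L6 cells (Rattus norvegicus) for activation, with a stated time of 90 min (on this read-out lower numbers stand for an effect already at smaller amounts and higher numbers for an effect only at larger amounts of compound), compound 2 gives 3000 nM, the highest of the two numbers; compound 1 gives 190 nM, a lower number, and the gap between them lies beyond the scatter. Compound 3 `O=[N+]([O-])c1cc(Nc2nc3nonc3nc2O)ccc1OC(F)(F)F` differs from compound 2 in one place: nitro in place of chloro on an aromatic carbon. Among the compounds with values here, no pair of measured compounds shows what this change does, so the direction of the step is not known from the data. The step from compound 2 to compound 3 is expected to be small, no change at the digits printed from compound 2 to compound 3 (within the scatter), not beyond the scatter. Compound 3 is therefore estimated at 3000 nM, within a range from 700 nM to 13000 nM.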

Compound 3, half-maximal effective concentration: 53500 nM
Compound 3: middle estimate off by 18-fold (1.25 log units), on the low side, outside the stated range (above it).
By their numbers in this assay, from the lowest: compound 1; then compound 2; then compound 3.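

In this assay, nitro in place of chloro on this aromatic carbon, ortho to a trifluoromethoxy group, gives an 18-fold higher number from compound 2 to compound 3 (1.25 log units; beyond the scatter) and so shows that the read-out is sensitive to which group sits at this position. Compound 1 and compound 2 differ in more than one place and could not show this. Nothing available here accounts for the size of the step. From the compounds shown here alone, it remains open whether an amine or a carboxylic acid on this carbon would give a number closer to compound 2 or to compound 3. Going by these compounds, it also remains open whether the same change would have a similar effect with other groups elsewhere on the molecule.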